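The source may hold more compounds than are shown below. What is called first, only, known or untested is meant among the compounds shown, and "the series" means these compounds.

Working notes on the series. For the measured compounds named here, compound 2 `COc1cc(-n2cnc3ccc(-c4cc(F)ccc4F)cc32)cc(OC)c1OC` gives 7940 nM in a functional assay on A549 cells (Homo sapiens) for antiproliferative activity, read by MTT assay, with a stated time of 72 h (a lower number here means a stronger inhibitor, a higher number a weaker inhibitor), the highest of the two numbers so far; its nearest neighbour is compound 1 `COc1cc(-n2cnc3ccc(-c4cccc(F)c4)cc32)cc(OC)c1OC`, which gives 5270 nM in this assay, and the step of a 1.5-fold higher number from compound 1 to compound 2 (0.18 log units; within the scatter) stays within the scatter. The next compound, compound 3 `COc1cc(-n2cnc3ccc(-c4cccc(C)c4C)cc32)cc(OC)c1OC`, differs from compound 2 by 2,3-dimethylphenyl in place of 2,5-difluorophenyl on an aromatic carbon. Going by the values given here, no measured step covers this kind of exchange: the only step available, from compound 1 to compound 2, concerns a fluoro in place of hydrogen on an aromatic carbon and was within the scatter, so the two numbers so far give no direction for a change of both substituents at once. The expectation is therefore a step of a 1.2-fold lower number from compound 2 to compound 3 (0.09 log units; within the scatter) that does not clearly leave the scatter, with wide uncertainty. Compound 3 is estimated at 6500 nM in this assay, in the range 2000 nM to 20000 nM.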

Compound 3, half-maximal inhibitory concentration: 9250 nM
For compound 3 the middle estimate is 1.4-fold (0.15 log units) below the measured one, within the range that was stated.
By their numbers in this assay, from the lowest: compounds 1, 2 and 3 (each within the scatter of the next).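

The exchange of 2,5-difluorophenyl for 2,3-dimethylphenyl goes beyond fluoro for hydrogen: it removes fluorine from this aryl group altogether, yet the number in this assay stays within the scatter (a 1.2-fold higher number from compound 2 to compound 3 (0.07 log units; within the scatter)), and the same holds against the monofluorinated aryl group (a 1.8-fold higher number from compound 1 to compound 3 (0.24 log units; within the scatter)). At this position on the shared core, the three substituted phenyl groups shown therefore cannot be told apart in this assay, whether they carry fluoro or methyl groups. Nothing available explains this lack of separation.

All three compounds carry a phenyl group with only fluoro or methyl substituents here, so the range of the position remains undefined. As far as these compounds go, whether a carboxylic acid or an aminomethyl group on this ring, or a saturated amine in place of it, would give a step beyond the scatter stays open.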